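The compounds below may be only part of what the source reports. "The series", "measured", "known", "first", "only" and "open" are said of these compounds alone.

Compound 1 `COC[C@@H](C(C)C)C(c1ccc(O)c(OC)c1)c1ccc(O)c(OC)c1` and compound 2 `COC[C@H](C(C)C)C(c1ccc(O)c(OC)c1)c1ccc(O)c(OC)c1` have the same atoms and bonds and differ only in the configuration drawn at one saturated chain carbon. In a functional assay on HL-60 cells (Homo sapiens) for cytotoxicity, read by WST assay, with a stated time of 48 h (a higher number here means a weaker inhibitor, a lower number a stronger inhibitor), compound 1 gives 54000 nM. In this assay compound 2 gives 72000 nM, the highest of the two plain numbers in this set, yet the step of a 1.3-fold higher number from compound 1 to compound 2 (0.12 log units; within the scatter) lies within the usual scatter, so neither compound can be called the stronger one (the fact that compounds 1 and 2 differ only in the configuration as drawn). Compound 3 `COc1ccc(C(c2ccc(OC)c(OC)c2)[C@H](C)[C@H](C)CO)cc1OC` carries the same chain that compound 4 carries but differs from it elsewhere in the molecule. For compound 3 this assay reports only a limit, > 100000 nM, not a number (the limit of > 100000 nM in this assay, at which 1 of the 3 values shown sits).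

Compound 4 `COc1cc(C(c2ccc(O)c(OC)c2)[C@@H](C)[C@@H](C)CO)ccc1O` has not yet been measured. Its change from compound 2 is 2-(hydroxymethyl)-1-methylpropyl in place of 1-(methoxymethyl)-2-methylpropyl on a saturated chain carbon bound to two aromatic carbons. Among the compounds with values here, no measured step covers this exchange of chains; the one measured step concerned the drawn configuration alone and stayed within the scatter. Compound 3, with the same chain, sits at the limit of the assay. The step of a 1.1-fold higher number from compound 2 to compound 4 (0.05 log units; within the scatter) is therefore expected to be small, with weak inhibition on both sides. Compound 4 is estimated at 80000 nM in this assay, within a range from 30000 nM to 200000 nM.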

Compound 4, half-maximal inhibitory concentration: > 100000 nM
Compound 4 was reported as a limit; the forecaster's own chance of this, stated with the estimate: 40%; middle value at least 1.2-fold (0.09 log units) from the limit.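

In this assay compound 4 gives > 100000 nM, which is a limit and not a number. Putting 2-(hydroxymethyl)-1-methylpropyl in place of 1-(methoxymethyl)-2-methylpropyl on a saturated chain carbon bound to two aromatic carbons gives an at least 1.3-fold higher number from compound 2 to compound 4 (0.14 log units; that floor lies within the scatter) and an at least 1.8-fold higher number from compound 1 to compound 4 (0.26 log units; that floor lies within the scatter), so this exchange of chains brings no sign of stronger inhibition, though these floors alone do not establish a real loss. Compound 3 and compound 4 carry the same chain and differ elsewhere in the molecule, yet neither gives a plain number: the limit of > 100000 nM in this assay, at which 2 of the 4 values shown sit.

On these data alone, how far compound 4 lies past the limit stays open, so the true size of both steps is unknown, and they could be small or large. Also open, as far as these compounds go, is whether a chain ending in an amine or a carboxylic acid, at this same place, would give a plain number, and whether the drawn configuration matters for the chain of compound 4 as little as the step between compound 1 and compound 2 suggests for theirs.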